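A Methoxy Group on a Series Sitting at the Limit

The compounds below may be only part of what the source reports. "The series", "measured", "known", "first", "only" and "open" are said of these compounds alone.

Compound 2, `O=C(Nc1cccc2cccnc12)c1ncccn1`, is the reference point. In a functional assay on PANC-1 cells (Homo sapiens) for inhibition, read by MTT assay, with a stated time of 72 h (a higher number here means a weaker inhibitor, a lower number a stronger inhibitor), compound 2 gives > 10000 nM, which is a limit of the assay rather than a measured number. Its two neighbours tell the same story. Compound 1, `O=C(Nc1cccc2cccnc12)c1cccnn1`, differs from it only in the ring attached to the carbonyl carbon; in this assay compound 1 gives > 10000 nM, again a limit. Compound 3, `Cc1ccc2cccc(NC(=O)c3ncccn3)c2n1`, carries a methyl in place of hydrogen on an aromatic carbon; in this assay compound 3 gives > 10000 nM, also a limit. Because (the limit of > 10000 nM in this assay, at which 3 of the 3 values shown sit), neither step can be sized: a step that the two limits leave unreadable from compound 1 to compound 2 and a step that the two limits leave unreadable from compound 2 to compound 3 both remain unreadable.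

Compound 4, `COc1cc(NC(=O)c2ncccn2)c2ncccc2c1`, is not yet measured. It differs from compound 2 by methoxy in place of hydrogen on an aromatic carbon. Among the compounds with values here, the two measured steps are the only guide, and both are unreadable, so they give no direction and no size. What they do show is that three compounds built around this shared core all sit at the limit, and a small change of this kind has not moved any of them off it. The expectation for compound 4 in this assay is therefore 15000 nM, within 5000 nM to 50000 nM, most probably reported once more as a limit. The expected step is a step that the limit leaves unreadable from compound 2 to compound 4, which is no change beyond the scatter.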

Compound 4, half-maximal inhibitory concentration: 9000 nM
Estimate against measurement, compound 4: 1.7-fold (0.22 log units) above; the range from low to high includes it.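

In this assay compound 4 gives 9000 nM, the only value among the compounds shown that is a number and not a limit. Within the data shown here, this gives the series its one fixed reading, with methoxy in place of hydrogen on an aromatic carbon of the six-membered ring of carbon only, while the methyl of compound 3 and the ring change of compound 1 offer no readable step. The change from hydrogen to methoxy is an at least 1.1-fold lower number from compound 2 to compound 4 (0.04 log units; that floor lies within the scatter), so it sets only a floor, and the true size of the step stays unknown because compound 2 has no number of its own: the limit of > 10000 nM in this assay, at which 3 of the 4 values shown sit.

As far as these compounds go, it remains open whether this reading belongs to methoxy itself or would also appear with a hydroxy group, an amine or a longer chain such as ethoxy on the same carbon. From the compounds shown here alone, it is also open how far the value would move with methoxy on the core of compound 1, or with methoxy and the methyl of compound 3 together, and the steps among compounds 1, 2 and 3 cannot be read.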